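Purine series: amino removal at the core of compound 1

The source may hold more compounds than are shown below. What is called first, only, known or untested is meant among the compounds shown, and "the series" means these compounds.

Measured so far:
compound 1 `Nc1nc(Cl)c2ncn(Cc3ccccc3CCl)c2n1` — 77600 nM
compound 2 `ClCc1ccc(Cn2cnc3c(Cl)nc(Cl)nc32)cc1` — 5750 nM

In a functional assay on Hs-578T cells (Homo sapiens) for cytotoxicity, read by sulforhodamine B assay, with a stated time of 48 h (a lower number here means a stronger inhibitor of growth, a higher number a weaker inhibitor of growth), compound 1 gives 77600 nM, the highest number of the two measured compounds. Compound 2 gives 5750 nM, a lower number; the gap between compound 1 and compound 2 lies beyond the scatter, but the two structures differ in more than one place, so no single step can be read from them.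

Compound 3 `ClCc1ccccc1Cn1cnc2c(Cl)ncnc21` has not yet been measured. It differs from compound 1 by hydrogen in place of amino on an aromatic carbon. The amino group is the only hydrogen-bond donor and acceptor that leaves; nothing takes its place beyond a hydrogen.

The direction of this step is open. Going by the values given here, compound 2, which carries no amino group on its core, gives a lower number than compound 1, and this is the only hint the measured pair offers. On that basis a modest decrease in the number is expected, the step from compound 1 to compound 3 being a 2.6-fold lower number from compound 1 to compound 3 (0.41 log units; beyond the scatter) in this assay. Compound 3 is therefore estimated at 30000 nM, with a range from 8000 nM to 110000 nM.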

Compound 3, concentration for total growth inhibition: 6600 nM
Compound 3: the middle estimate sits 4.5-fold (0.66 log units) above what was measured, and the stated range ends above it.
By their numbers in this assay, from the lowest: compounds 2 and 3 (each within the scatter of the next); then compound 1.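

In this assay, the series now has its first step that can be tied to one place: hydrogen in place of amino on an aromatic carbon, between two ring nitrogen atoms, gives a 12-fold lower number from compound 1 to compound 3 (1.07 log units; beyond the scatter), a large step beyond the scatter. Compound 1 and compound 2 differ in more than one place and could not show this, whereas here the whole change in number belongs to this one position, and growth inhibition in these cells does not depend on the amino group there. No measurement bears on why this exchange has so large an effect, so the step stands as an observation without an explanation.

On these data alone, at this carbon only amino and hydrogen can be compared directly, so it remains open whether a methylamino or a methoxy group would give a number close to that of compound 3 or close to that of compound 1. The chloro group that compound 2 carries at this carbon cannot be read as a step, as compound 2 differs from both compound 1 and compound 3 in more than one place.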